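Lengthening the Chain on Compound 2 by One Carbon

This account rests on a few compounds, and the source may have more. Where it says the series, first, only, none or still open, it means among the compounds named here.

Two compounds share one core and differ only in the group on an aromatic carbon. Compound 1 `CC(C)c1ccc(NC(=O)N[C@H](C)c2ccccc2)cc1` carries an isopropyl there, and in an ADME assay on the whole organism with Oryza sativa as the target, tested at 1 uM (on this read-out higher numbers stand for a weaker effect at the one concentration tested and lower numbers for a stronger effect), compound 1 gives 79%. Compound 2 `CCCCc1ccc(NC(=O)N[C@H](C)c2ccccc2)cc1` carries a butyl, and in this assay compound 2 gives 32%. Among the measured compounds shown here, the only measured comparison is a number 47 percentage points lower from compound 1 to compound 2 (beyond the scatter). On the numbers shown, compound 2 stands lowest of the two, with compound 1 as its nearest neighbour above it, beyond the scatter.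

Compound 3 `CCCCCc1ccc(NC(=O)N[C@H](C)c2ccccc2)cc1` has not yet been measured. It differs from compound 2 by methyl in place of hydrogen on a saturated chain carbon, four bonds along the chain from an aromatic carbon. The measured step bears on this only loosely, because a number 47 percentage points lower from compound 1 to compound 2 (beyond the scatter) combined a change from branched to straight with a change in chain length, whereas compound 3 lengthens the chain alone by a single carbon. The coming step is expected to be smaller than that one and, if anything, downward, though it may well stay within the scatter. The estimate for compound 3 in this assay is 24%, with a range from 5% to 48%, which means an expected step of a number 8 percentage points lower from compound 2 to compound 3 (within the scatter).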

Compound 3, a percentage reported as activity, at one concentration (the size of the read-out at that concentration, not a potency): 101%
Compound 3: middle estimate off by 77 percentage points, on the low side; measured number outside the range, above it.
By their numbers in this assay, from the lowest: compound 2; then compound 1; then compound 3.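

At the place four bonds along the chain from an aromatic carbon, methyl in place of hydrogen gives, in this assay, a number 69 percentage points higher from compound 2 to compound 3 (beyond the scatter) and so shows that this small change at the end of the chain can move the read-out further than the change from isopropyl to butyl, which gave a number 47 percentage points lower from compound 1 to compound 2 (beyond the scatter) in the opposite direction. The three compounds therefore do not follow chain length in one direction, for butyl stands lowest while pentyl gives a number 22 percentage points higher from compound 1 to compound 3 (beyond the scatter) and lies above even the branched isopropyl, so compound 2 alone goes against any trend that runs upward from compound 1 to compound 3. No measurement at hand says why the number turns upward at this position.

Going by these compounds, what remains open is whether the low number belongs to butyl alone or is shared by nearby chain lengths, a question that a propyl or a hexyl chain on the same aromatic carbon would address. On these data alone, it also remains open whether the upward turn depends on the length of the chain or on its end, which a pentyl chain ending in a hydroxyl group or an amine could begin to separate.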